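Aryl ether naphthoquinones: furan to thiophene, topoisomerase inhibition

The compounds below may be only part of what the source reports. "The series", "measured", "known", "first", "only" and "open" are said of these compounds alone.

Measured so far:
- compound 1, `O=C1C=CC(=O)c2cc(OCc3ccccc3)ccc21`: 53700 nM
- compound 2, `O=C1C=CC(=O)c2cc(Oc3ccco3)ccc21`: > 100000 nM (a limit of the assay, not a number)

In an assay on isolated protein for inhibition of DNA topoisomerase 1 (Homo sapiens) (on this read-out higher numbers stand for weaker inhibition and lower numbers for stronger inhibition), compound 1 gives 53700 nM. For compound 2 this assay returns only the limit > 100000 nM, as shown at the limit of > 100000 nM in this assay, at which 1 of the 2 values shown sits, so no number stands for it. Compound 3, `O=C1C=CC(=O)c2cc(Oc3cccs3)ccc21`, has not been measured; it differs from compound 2 in thiophen-2-yl in place of furan-2-yl on an oxygen on an aromatic ring. Going by the values given here, no step between measured compounds is available, and compound 1 differs from compound 2 in more than one place, so the two values show only that compound 2 sits at the limit while compound 1 lies within the measurable range. For the step from compound 2 to compound 3 no change beyond the scatter in this assay is expected, a number no higher from compound 2 to compound 3 (the limit leaves the size open). Compound 3 is expected to give about 100000 nM, within 40000 nM to 300000 nM, with a limit rather than a number the likelier outcome.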

Compound 3, half-maximal inhibitory concentration: > 100000 nM
Compound 3 gave a limit, no number; the forecaster's own chance of this, stated with the estimate: 65%; the middle value sits exactly at the limit.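

In this assay, compound 2 and compound 3 both return a limit of the assay, not a number, so no step between them can be read: the limit of > 100000 nM in this assay, at which 2 of the 3 values shown sit.

The compounds shown leave open whether thiophen-2-yl in place of furan-2-yl changes inhibition at all.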